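Compound 4: tert-butyl replaces dimethylamino

A few compounds are considered here, and "the series" means these few. Any claim that something is new, unique, unknown or untested is made for them only; others in the source may bear on it.

Measured so far (a functional assay on HT-29 cells (Homo sapiens) for antiproliferative activity, read by MTT assay, with a stated time of 96 h; a higher number here means a weaker inhibitor, a lower number a stronger inhibitor):
Compound 1 (`COc1ccc(N2C(=O)NC3(CSC4=C3C(=O)c3ncccc3C4=O)C2=O)cc1`) gives 2 nM
Compound 2 (`O=C1NC(=O)C2(CSC3=C2C(=O)c2ncccc2C3=O)N1`) gives 190 nM; 180 nM; 190 nM (3 entries)
Compound 3 (`CN(C)c1ccc(N2C(=O)NC3(CSC4=C3C(=O)c3ncccc3C4=O)C2=O)cc1`) gives 20 nM

Of the two compounds with a single number, compound 3 has the higher value (20 nM), which means the weaker inhibition. Its nearest neighbour is reached by one swap, dimethylamino in place of methoxy on an aromatic carbon (a 10-fold higher number from compound 1 to compound 3 (1.00 log units; beyond the scatter)). Compound 2 was measured repeatedly (the several entries of compound 2 in this assay, 190 nM; 180 nM; 190 nM (3 entries)), and those values lie above that of compound 3.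

Compound 4 (`CC(C)(C)c1ccc(N2C(=O)NC3(CSC4=C3C(=O)c3ncccc3C4=O)C2=O)cc1`) has not yet been measured. In it, tert-butyl takes the place of dimethylamino on an aromatic carbon (tert-butyl in place of dimethylamino on an aromatic carbon). Among the compounds with values here, only one measured step bears on this place (a 10-fold higher number from compound 1 to compound 3 (1.00 log units; beyond the scatter)). It shows that a swap here can move the number well beyond the scatter, but it does not show which way tert-butyl should go. A shift of similar size is therefore possible in either direction. The estimated step is centred on no clear change (no change at the digits printed from compound 3 to compound 4 (within the scatter)), with wide margins. In this assay the expected value for compound 4 is 20 nM (estimated range 4 nM to 100 nM).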

Compound 4, half-maximal inhibitory concentration: 150 nM
Estimate against measurement, compound 4: 7.5-fold (0.88 log units) below; measured number outside the range, above it.
By their numbers in this assay, from the lowest: compound 1; then compound 3; then compound 4.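

Replacing dimethylamino with tert-butyl in this assay gives a 7.5-fold higher number from compound 3 to compound 4 (0.88 log units; beyond the scatter), so a second swap at this place also moves the number beyond the scatter, this time with a group of carbon only. Against the methoxy compound the change is larger, a 75-fold higher number from compound 1 to compound 4 (1.88 log units; beyond the scatter), which puts the three aromatic groups in a clear order and shows that a substituent here can decide much of the activity. These gaps are far wider than the spread among repeated readings of one compound: the several entries of compound 2 in this assay, 190 nM; 180 nM; 190 nM (3 entries)

The swap changes the atom count and removes a hydrogen-bond acceptor together, so these compounds cannot show which of the two matters. Going by these compounds, how a halogen such as chlorine, a carboxylic acid or a primary amine would behave at this place also remains open.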